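Cytotoxicity of a chloro-to-dimethylamino swap on the core

The compounds below may be only part of what the source reports. "The series", "measured", "known", "first", "only" and "open" are said of these compounds alone.

Of the compounds shown here, three sharing one core have been measured in an ADME assay on H9 cells (Homo sapiens) for cytotoxicity, read by MTT assay, with a stated time of 7 days; on this read-out higher numbers stand for lower toxicity in this test and lower numbers for higher toxicity in this test. Compound 1 `COc1ccccc1NC(=O)c1cc(NC(C)=O)ccc1Sc1ccc([N+](=O)[O-])cc1` gives 171000 nM. Compound 2 `COc1ccccc1NC(=O)c1cc(N)ccc1Sc1ccc([N+](=O)[O-])cc1` gives 506000 nM. Compound 3 `COc1ccccc1NC(=O)c1cc(Cl)ccc1Sc1ccc([N+](=O)[O-])cc1` gives 483000 nM, which places it second highest of the three: its nearest neighbour is compound 2, the pair lying within the scatter, while compound 1 sits furthest away, a 2.8-fold higher number from compound 1 to compound 3 (0.45 log units; beyond the scatter). The other steps are a 3.0-fold higher number from compound 1 to compound 2 (0.47 log units; beyond the scatter) and a 1.0-fold lower number from compound 2 to compound 3 (0.02 log units; within the scatter).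

Compound 4 `COc1ccccc1NC(=O)c1cc(N(C)C)ccc1Sc1ccc([N+](=O)[O-])cc1` differs from compound 3 by dimethylamino in place of chloro on an aromatic carbon. For the measured compounds named here, no measured step exchanges chloro for dimethylamino, so the nearest guide is the swap between two small substituents at the same place, a 1.0-fold lower number from compound 2 to compound 3 (0.02 log units; within the scatter), which stayed within the scatter; only the acetamido of compound 1 shifted the number, a 3.0-fold higher number from compound 1 to compound 2 (0.47 log units; beyond the scatter). The author therefore expects no step beyond the scatter, a 1.2-fold lower number from compound 3 to compound 4 (0.08 log units; within the scatter), and estimates compound 4 at 400000 nM, within 150000 nM to 900000 nM.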

Compound 4, half-maximal cytotoxic concentration: 182000 nM
Compound 4: middle estimate off by 2.2-fold (0.34 log units), on the high side; low and high end bracket the measured number.
By their numbers in this assay, from the lowest: compounds 1 and 4 (each within the scatter of the next); then compounds 3 and 2 (each within the scatter of the next).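

In this assay chloro and amino had matched each other on this aromatic carbon, but dimethylamino does not stay with them, giving a 2.7-fold lower number from compound 3 to compound 4 (0.42 log units; beyond the scatter) and a 2.8-fold lower number from compound 2 to compound 4 (0.44 log units; beyond the scatter) as its two steps. The lower numbers are therefore not confined to acetamido, since dimethylamino and acetamido stand together with a 1.1-fold higher number from compound 1 to compound 4 (0.03 log units; within the scatter) as the step that joins them. Nothing available here accounts for why these groups separate in this way.

The compounds shown leave open whether a single methyl on the nitrogen, as in methylamino, already brings the number down to that of compound 4 or leaves it with compound 2. They also leave open whether a larger amine such as diethylamino moves the number further from that of compound 4.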